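Topoisomerase 1 inhibition: thiophenyl to pyridinyl exchange

A few compounds are considered here, and "the series" means these few. Any claim that something is new, unique, unknown or untested is made for them only; others in the source may bear on it.

Measured compounds:
compound 1 `Oc1cccc(-c2cc(-c3cccnc3)nc(-c3cccc(Cl)c3)c2)c1` — 27.6%
compound 2 `Oc1ccc(-c2cc(-c3cccc(Cl)c3)nc(-c3cccs3)c2)cc1` — 52.4%

Of the compounds shown here, two have been tested in an assay on isolated protein for inhibition of DNA topoisomerase 1 (Homo sapiens), with a stated time of 30 min, tested at 100 uM; a higher number here means a stronger effect of the compound at the concentration tested, a lower number a weaker effect. Compound 1 `Oc1cccc(-c2cc(-c3cccnc3)nc(-c3cccc(Cl)c3)c2)c1` gives 27.6% in this assay, and compound 2 `Oc1ccc(-c2cc(-c3cccc(Cl)c3)nc(-c3cccs3)c2)cc1` gives 52.4%. Compound 2 thus stands highest of the two numbers, and its nearest neighbour, compound 1, lies a step below it that is beyond the usual scatter. For the measured compounds named here, no single-point step between measured compounds is available, so the two values can only be read side by side.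

The next compound, compound 3 `Oc1ccc(-c2cc(-c3cccnc3)nc(-c3cccc(Cl)c3)c2)cc1`, is not yet measured. Relative to compound 2 it changes in one place: pyridin-3-yl in place of thiophen-2-yl on an aromatic carbon

Going by the values given here, since no measured step covers this exchange, the size of the change in this assay is open. Among the compounds with values here, compound 3 is expected to lose some inhibition, by a step of a number 14.4 percentage points lower from compound 2 to compound 3 (beyond the scatter), because compound 1 gives 27.6% as the only measured compound carrying pyridin-3-yl, a markedly lower reading. The estimate for compound 3 in this assay is therefore 38%, with a range from 15% to 60%.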

Compound 3, a percentage reported as inhibition, at one concentration (the size of the read-out at that concentration, not a potency): 55.2%
Compound 3: middle estimate off by 17.2 percentage points, on the low side; the range from low to high includes it.
By their numbers in this assay, from the lowest: compound 1; then compounds 2 and 3 (each within the scatter of the next).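

In this assay the exchange of thiophen-2-yl for pyridin-3-yl, on the aromatic carbon next to the ring nitrogen, reads as a number 2.8 percentage points higher from compound 2 to compound 3 (within the scatter) and so does not separate the two rings at this position, although pyridin-3-yl is the larger group by its heavy atoms. The low reading of compound 1 therefore does not go with pyridin-3-yl alone: with that group kept, 4-hydroxyphenyl in place of 3-hydroxyphenyl gives a number 27.6 percentage points higher from compound 1 to compound 3 (beyond the scatter) and moves the difference to the hydroxyphenyl group. Nothing in the data bears on why either step has the size it has.

As far as these compounds go, whether pyridin-3-yl and thiophen-2-yl also read alike with 3-hydroxyphenyl in place of 4-hydroxyphenyl remains open, and these readings at a single concentration give no potency for any of the compounds. The compounds shown also leave open what a methoxy group in place of the hydroxyl, or an amine on the pyridin-3-yl ring, would do to the inhibition.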